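Hexyloxy to Methyl on the Shared Core

A few compounds are considered here, and "the series" means these few. Any claim that something is new, unique, unknown or untested is made for them only; others in the source may bear on it.

Compound 2 `CCCCCCOc1ccc(NS(=O)(=O)c2ccc(N3CCNC3=O)cc2)cc1` reaches only a limit in a functional assay on HT-29 cells (Homo sapiens) for antiproliferative activity, read by sulforhodamine B assay, with a stated time of 48 h (a lower number here means a stronger inhibitor, a higher number a weaker inhibitor), recorded as > 1000 nM. That limit is the limit of > 1000 nM in this assay, at which 1 of the 2 values shown sits. Compound 1 `CCc1ccc(NS(=O)(=O)c2ccc(N3CCNC3=O)cc2)cc1` gives 660 nM in this assay. Among the measured compounds shown here, the one measured step that bears on the present change is an at least 1.5-fold higher number from compound 1 to compound 2 (0.18 log units; that floor lies within the scatter). The change to compound 3 `Cc1ccc(NS(=O)(=O)c2ccc(N3CCNC3=O)cc2)cc1` is methyl in place of hexyloxy on an aromatic carbon. Since the step from ethyl to hexyloxy weakened inhibition, a return toward a small alkyl group is expected to lower the number, an at least 1.4-fold lower number from compound 2 to compound 3 (0.15 log units; that floor lies within the scatter). Compound 3 is therefore estimated at 700 nM, within a range from 300 nM to 2000 nM.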

Compound 3, half-maximal inhibitory concentration: 480 nM
Compound 3: middle estimate off by 1.5-fold (0.16 log units), on the high side; measured number inside the range.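

In this assay, methyl in place of hexyloxy gives an at least 2.0-fold lower number from compound 2 to compound 3 (0.31 log units; beyond the scatter), so this position now shows a step that clears the scatter, as the floor of the step from ethyl to hexyloxy did not. The two small alkyl groups are not separated, with a 1.4-fold lower number from compound 1 to compound 3 (0.14 log units; within the scatter). The value of compound 2 is a limit, so the step from it gives only a floor: the limit of > 1000 nM in this assay, at which 1 of the 3 values shown sits.

The compounds shown leave open whether a methoxy group, a butyl chain or an amine at this position would read like methyl and ethyl or like hexyloxy.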